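This account rests on a few compounds, and the source may have more. Where it says the series, first, only, none or still open, it means among the compounds named here.

Compound 1 `CCOC(=O)/C(O)=C/C(=O)c1cn(Cc2cc(F)cc(F)c2)c2cccc(OC)c12` in an ADME assay on MT4 cells (Homo sapiens) for cytotoxicity, read by MTT assay (on this read-out higher numbers stand for lower toxicity in this test and lower numbers for higher toxicity in this test), gives 34700 nM; compound 2 `COc1cccc2c1c(C(=O)/C=C(\O)C(=O)O)cn2Cc1cc(F)cc(F)c1` gives 29500 nM; compound 3 `COc1cccc2c1c(C(=O)/C=C(\O)C(=O)O)cn2Cc1cc(F)c(F)c(F)c1` gives 23300 nM.

Compound 1 holds the highest of the three numbers in this assay, though its gaps to compound 2 and compound 3 both lie within the scatter. The two measured steps, a 1.2-fold lower number from compound 1 to compound 2 (0.07 log units; within the scatter) and a 1.3-fold lower number from compound 2 to compound 3 (0.10 log units; within the scatter), were likewise within the scatter. Compound 4 `CCOC(=O)/C(O)=C/C(=O)c1cn(Cc2ccc(F)cc2F)c2cccc(OC)c12` differs from compound 1 by 2,4-difluorophenyl in place of 3,5-difluorophenyl on a saturated chain carbon bound to an aromatic nitrogen. Within the data shown here, no measured step touches that same ring in that same way; the nearest is a 1.3-fold lower number from compound 2 to compound 3 (0.10 log units; within the scatter), and it too stayed flat. Since every change so far left this assay essentially unmoved, no step beyond the scatter is expected here, and the estimated step is a 1.2-fold lower number from compound 1 to compound 4 (0.06 log units; within the scatter). Compound 4 is therefore expected at 30000 nM, with a range from 15000 nM to 60000 nM.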

Compound 4, half-maximal cytotoxic concentration: 65500 nM
The estimate for compound 4 lay 2.2-fold (0.34 log units) below the measured number, outside the stated range (above it).
By their numbers in this assay, from the lowest: compounds 3, 2, 1 and 4 (each within the scatter of the next, the first and the last beyond it).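

Rearranging the two fluorines on the benzyl group, with the atoms themselves unchanged, gives a 1.9-fold higher number from compound 1 to compound 4 (0.28 log units; within the scatter) in this assay. Among these compounds, the earlier steps concerned the ester and an added fluoro, so this is the first reading at this position on a saturated chain carbon bound to an aromatic nitrogen, and the swap from 3,5-difluorobenzyl to 2,4-difluorobenzyl stays within the scatter. Nothing available explains the outcome.

The compounds shown leave open how this position responds to an unsubstituted benzyl group or a longer alkyl chain. They also leave open whether the same swap behaves alike when the carboxylic acid of compound 2 replaces the ethyl ester.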